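From compound 2 to compound 4: one side chain changes

The source may hold more compounds than are shown below. What is called first, only, known or untested is meant among the compounds shown, and "the series" means these compounds.

Compound 1 `CCCCCCCCCCCCCC(=O)NC(CO[C@@H]1O[C@H](CO)[C@H](O)[C@H](O)[C@H]1O)C(=O)NCCOS(=O)(=O)O`: > 100000 nM
Compound 2 `CCCCCCCCCCCCCCNC(=O)C(CO[C@@H]1O[C@H](CO)[C@H](O)[C@H](O)[C@H]1O)NC(=O)CCCCCCCCCCC(=O)O`: > 100000 nM
Compound 3 `O=C(O)CCCCCCCCCCC(=O)N(CCCCCCCC(F)(F)C(F)(F)C(F)(F)C(F)(F)C(F)(F)C(F)(F)C(F)(F)C(F)(F)F)CCO[C@@H]1O[C@H](CO)[C@H](O)[C@H](O)[C@H]1O`: > 18000 nM

All three values come from a functional assay on CEM-SS cells (Homo sapiens) for cytotoxicity (on this read-out lower numbers stand for higher toxicity in this test and higher numbers for lower toxicity in this test), and each one is a limit of the assay, not a number. Compound 2 reads > 100000 nM, which is such a limit. Compound 2 shares its place with compound 1, as the limit of > 100000 nM in this assay, at which 2 of the 3 values shown sit, shows. Compound 3 has a limit of its own, recorded as the limit of > 18000 nM in this assay, at which 1 of the 3 values shown sits.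

Compound 4 `CCCCCCCCCCCCCCNC(=O)C(CO[C@@H]1O[C@H](CO)[C@H](O)[C@H](O)[C@H]1O)NC(=O)CCC(=O)NCCS(=O)(=O)O` keeps most of compound 2 and alters one side chain: (2-sulfoethyl)carbamoyl in place of 8-carboxyoctyl on a saturated chain carbon, two bonds along the chain from a carbonyl carbon. In words, (2-sulfoethyl)carbamoyl stands in place of 8-carboxyoctyl on a saturated chain carbon, two bonds along the chain from a carbonyl carbon.

For the measured compounds named here, no measured pair of compounds offers a step to compare, and no compound here has yet given a number in this assay. The expectation therefore starts from compound 2 at > 100000 nM, again a limit. No change beyond the scatter is expected in either direction, so the expected a number no higher from compound 2 to compound 4 (the limit leaves the size open) is small, and another limit is the likeliest report. For compound 4 the estimate is 100000 nM, with an expected range from 40000 nM to 200000 nM.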

Compound 4, half-maximal cytotoxic concentration: > 100000 nM
Compound 4: no number, only a limit; the forecaster's own chance of this, stated with the estimate: 85%; the middle value lies on the limit itself.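

In this assay, compound 2 and compound 4 each give only a limit of the assay, not a number, and the step between them cannot be read. The compounds shown leave open what putting (2-sulfoethyl)carbamoyl in place of 8-carboxyoctyl does to this read-out, and at what concentration any of these compounds would harm the cells.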